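Thiophene thiosemicarbazones: aryl substitution and growth inhibition

The source may report more compounds than this note shows. Statements on the series, on what has been measured and on what is new or still open speak of the compounds shown alone.

Compound 1 `S=C(N/N=C/c1cccs1)Nc1ccccc1` is the plain aryl member of the series. In a functional assay on NCI/ADR-RES cells (Homo sapiens) for inhibition, read by sulforhodamine B assay, with a stated time of 48 h (a higher number here means a weaker inhibitor of growth, a lower number a stronger inhibitor of growth), compound 1 gives only > 100000 nM, which is a limit of the assay rather than a number. Compound 3 `C=CCNC(=S)N/N=C/c1cccs1`, the allyl member, likewise returns only a limit in this assay, > 100000 nM. Among the compounds with values here, compound 2 `S=C(N/N=C/c1cccs1)Nc1cccc2ccccc12`, carrying the larger fused aromatic group, is the one member with a measured number, 6600 nM in this assay. Compound 1 therefore stands at the limit of > 100000 nM in this assay, at which 2 of the 3 values shown sit; the two limit values say nothing about any order between compound 1 and compound 3.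

Compound 4 `S=C(N/N=C/c1cccs1)Nc1ccc(Cl)cc1` differs from compound 1 by chloro in place of hydrogen on an aromatic carbon. Within the data shown here, no step between measured compounds of this kind is available, and the single measured number in the set belongs to a member with a different sort of change, so nothing here fixes the size of the effect. The expectation is a step toward stronger growth inhibition that is modest at best, with a fair chance that compound 4 also returns only a limit in this assay. For compound 4 the estimate in this assay is 60000 nM, with a range from 10000 nM to 200000 nM. The expected step is an at least 1.6-fold lower number from compound 1 to compound 4 (0.22 log units; that floor lies within the scatter) in this assay.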

Compound 4, concentration for 50% growth inhibition: 2800 nM
For compound 4 the middle estimate is 21-fold (1.33 log units) above the measured one; measured number outside the range, below it.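

In this assay, chloro in place of hydrogen on an aromatic carbon, para to a large group, gives an at least 35-fold lower number from compound 1 to compound 4 (1.55 log units; beyond the scatter), so this position on the six-membered aromatic ring of carbon only responds strongly to a single added chlorine atom, with no ring added. Until now, a measured number had appeared in the series only with the larger fused aromatic group of compound 2, whereas compound 4 shows that one atom at this position is also enough to bring the plain aryl member off the limit. The step is a floor and its true size stays unknown because compound 1 has only a limit of the assay and no number: the limit of > 100000 nM in this assay, at which 2 of the 4 values shown sit.

Going by these compounds, whether the gain belongs to chloro itself or would follow from any group at this position stays open, and fluoro, methyl, methoxy or an amine in the same place would separate the two readings. Also open, on these data alone, is whether chloro at another place on the same ring, or on the fused aromatic group of compound 2, gives a step of similar size.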